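The source may hold more compounds than are shown below. What is called first, only, known or untested is meant among the compounds shown, and "the series" means these compounds.

Compound 3 `O=c1nc2oc(CCCCCCCCCCl)cc2cn1[C@H]1C[C@H](O)[C@@H](CO)O1` carries a chloro group at the end of a long saturated chain. In a functional assay for cytotoxicity, read by microscopy (on this read-out higher numbers stand for lower toxicity in this test and lower numbers for higher toxicity in this test), compound 3 gives only a limit, > 200000 nM, which is the limit of > 200000 nM in this assay, at which 1 of the 3 values shown sits. Two close relatives are measured alongside it. Compound 1 `CCCCCCCCCCc1cc2cn([C@H]3C[C@H](O)[C@@H](CO)O3)c(=O)nc2o1`, with a methyl in the same place, gives a limit of > 50000 nM in this assay. Compound 2 `O=c1nc2oc(CCCCCCCCCF)cc2cn1[C@H]1C[C@H](O)[C@@H](CO)O1`, with a fluoro in that place, likewise gives a limit of > 50000 nM in this assay. Those two values sit at the limit of > 50000 nM in this assay, at which 2 of the 3 values shown sit. Since every value is a limit rather than a number, the steps a step that the two limits leave unreadable from compound 1 to compound 2, a step that the two limits leave unreadable from compound 1 to compound 3 and a step that the two limits leave unreadable from compound 2 to compound 3 cannot be sized; all that is known is that no toxicity appeared up to each limit.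

Compound 4 `O=c1nc2oc(CCCCCCCCCBr)cc2cn1[C@H]1C[C@H](O)[C@@H](CO)O1` differs from compound 3 by a single exchange: bromo in place of chloro on a saturated chain carbon, nine bonds along the chain from an aromatic carbon. The nearest kin to this exchange is the halogen-for-halogen step from compound 2 to compound 3, yet it too is unreadable, so no direction or size beyond the scatter can be foreseen. Compound 4 is expected to give about 150000 nM, with a range from 50000 nM to 400000 nM, and most likely again as a limit. The expected step is therefore an at least 1.3-fold lower number from compound 3 to compound 4 (0.12 log units; that floor lies within the scatter), meaning no change beyond the scatter.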

Compound 4, minimum cytotoxic concentration: > 200000 nM
Compound 4 was reported as a limit (the forecaster's own chance of this, stated with the estimate: 85%); middle value at least 1.3-fold (0.12 log units) from the limit.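

In this assay compound 4 gives > 200000 nM, which is a limit. Among the compounds shown here, no step between compound 4 and compound 1, compound 2 or compound 3 can be read, since the values of those three are limits as well. The compounds shown leave open whether methyl, fluoro, chloro and bromo at the chain end differ at all in this assay, and at what concentration any toxicity would appear.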